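The source may hold more compounds than are shown below. What is called first, only, known or untested is meant among the compounds shown, and "the series" means these compounds.

Compound 1 `O=C(c1ccco1)N1CCN(C2CC(=O)N(c3ccc(-c4ccc(F)nc4)cc3)C2)CC1`: in an assay on isolated protein for inhibition of Monoglyceride lipase (Mus musculus), with a stated time of 30 min (on this read-out higher numbers stand for weaker inhibition and lower numbers for stronger inhibition), compound 1 gives 127 nM.
Compound 2 `COc1cccc(-c2cccc(N3CC(N4CCN(c5ncccn5)CC4)CC3=O)c2)c1`: in this assay compound 2 gives 39 nM.

Compound 2 stands lowest of the two numbers; the nearest is compound 1, whose number is higher by a margin beyond the usual scatter. Compound 3 `O=C1CC(N2CCN(c3ncccn3)CC2)CN1c1cccc(-c2cccnc2F)c1` is not yet measured in this assay. It differs from compound 2 in one place: 2-fluoropyridin-3-yl in place of 3-methoxyphenyl on an aromatic carbon. Going by the values given here, no step between measured compounds follows this change, so its size is not known from the data. Compound 3 is expected to give 65 nM in this assay, within 20 nM to 220 nM. This estimate means a 1.7-fold higher number from compound 2 to compound 3 (0.22 log units; within the scatter), expected to be a modest loss that may not exceed the scatter.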

Compound 3, half-maximal inhibitory concentration: 305 nM
The estimate for compound 3 lay 4.7-fold (0.67 log units) below the measured number; measured number outside the range, above it.
By their numbers in this assay, from the lowest: compound 2; then compound 1; then compound 3.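

In this assay, placing 2-fluoropyridin-3-yl instead of 3-methoxyphenyl on this aromatic carbon gives a 7.8-fold higher number from compound 2 to compound 3 (0.89 log units; beyond the scatter). The number therefore responds to the aryl group at this position, which compound 1 and compound 2 could not show, as they differ in more than one place. No measurement on hand accounts for the size of this step.

As far as these compounds go, the change alters the ring atoms and the substituent together, so the part responsible stays open. An unsubstituted phenyl or a pyridin-3-yl without the fluorine on this carbon would separate the two.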